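The source may hold more compounds than are shown below. What is called first, only, known or untested is meant among the compounds shown, and "the series" means these compounds.

Measured so far:
compound 1, `COc1ccc2nc(Cl)c(/C=C\c3cccc(C(F)(F)F)c3)cc2c1`: 3910 nM
compound 2, `COc1ccc2nc(Cl)c(/C=C\c3cc(C(F)(F)F)cc(C(F)(F)F)c3)cc2c1`: 5790 nM
compound 3, `COc1ccc2nc(Cl)c(/C=C\c3ccc(C(F)(F)F)cc3C(F)(F)F)cc2c1`: > 50000 nM

In a functional assay on MDA-MB-468 cells (Homo sapiens) for antiproliferative activity, read by sulforhodamine B assay, with a stated time of 72 h (on this read-out lower numbers stand for stronger inhibition and higher numbers for weaker inhibition), compound 1 gives 3910 nM and compound 2 gives 5790 nM. For compound 3 this assay reports only a limit, > 50000 nM. Compound 2 and compound 1 differ by one change, (hydrogen in place of trifluoromethyl on an aromatic carbon), and that step is a 1.5-fold lower number from compound 2 to compound 1 (0.17 log units; within the scatter). The difference between the core of compound 3 and that of compound 2 is not broken down here.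

Compound 4, `COc1ccc2nc(Cl)c(/C=C\c3ccccc3C(F)(F)F)cc2c1`, is not yet measured. It arises from compound 3 by hydrogen in place of trifluoromethyl on an aromatic carbon. This is the same kind of change as from compound 2 to compound 1, but not the same: there the place was meta to a large group and meta to a trifluoromethyl group, here it is meta to a trifluoromethyl group and para to a large group.

Because compound 3 sits at the limit of > 50000 nM in this assay, at which 1 of the 3 values shown sits, the step to compound 4 cannot be measured in full, and the earlier step offers no firm anchor for a different place. Compound 4 is estimated at 20000 nM, between 6000 nM and 50000 nM, which is an expected step of an at least 2.5-fold lower number from compound 3 to compound 4 (0.39 log units; beyond the scatter).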

Compound 4, half-maximal inhibitory concentration: 4980 nM
Beside the measured number, compound 4's estimate is 4.0-fold (0.60 log units) above it; measured number below the stated range.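

Replacing a trifluoromethyl group with hydrogen in this assay gives an at least 10-fold lower number from compound 3 to compound 4 (1.00 log units; beyond the scatter), so this change does not carry over at one size from core to core: the same change on two cores in this assay, a 1.5-fold lower number (0.17 log units; within the scatter) from compound 2 to compound 1 and an at least 10-fold lower number (1.00 log units; beyond the scatter) from compound 3 to compound 4, at least 6.7-fold (0.83 log units) apart, beyond the scatter of two such steps

Compound 3 has only a limit, > 50000 nM, so the size of its step is a minimum and not an exact figure: the limit of > 50000 nM in this assay, at which 1 of the 4 values shown sits.

Two pairs make no rule for other cores in this series, the place of the change is not the same in the two pairs, and the numbers alone do not say why the two steps differ.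

The compounds shown leave open what happens when the same place carries something other than hydrogen or trifluoromethyl, such as an amine, a carboxylic acid or a methoxy group. They also leave open how a ring with no trifluoromethyl group at all would compare in this assay.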